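A few compounds are considered here, and "the series" means these few. Any claim that something is new, unique, unknown or untested is made for them only; others in the source may bear on it.

Working notes on the amine-linked series in an assay for inhibition of 6-phosphofructo-2-kinase/fructose-2,6-bisphosphatase 3 (Homo sapiens), read by ADP-Glo, with a stated time of 2 h; a higher number here means a weaker inhibitor, a lower number a stronger inhibitor.

Of the compounds shown here, three share the same core and have been measured. Compound 1 `CN1CCC(CNS(=O)(=O)c2ccccc2Nc2cc(-c3ccc4ccn(C)c4c3)c3nccnc3c2)C1` gives 11 nM in this assay. Compound 2 `Cn1ccc2ccc(-c3cc(Nc4ccccc4S(=O)(=O)N4CCOCC4)cc4nccnc34)cc21` gives 36 nM. Compound 3 `Cn1cc(NC(=O)c2ccncc2Nc2cc(-c3ccc4ccn(C)c4c3)c3nccnc3c2)cn1`, the amide-type member of the set, gives 33 nM.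

Among the measured compounds shown here, the one step between measured neighbours is a 3.3-fold higher number from compound 1 to compound 2 (0.51 log units; beyond the scatter); it sits on the sulfonyl sulfur and says nothing about the amide side of the series.

Compound 3 stands second highest of the three numbers. Its value and that of compound 2 lie within the scatter of each other, so no order between them is claimed; compound 1 shows a lower number than compound 3, and that gap is beyond the scatter.

Compound 4 `CN1CCC(NC(=O)c2ccncc2Nc2cc(-c3ccc4ccn(C)c4c3)c3nccnc3c2)CC1=O` is not yet measured. It differs from compound 3 by 1-methyl-2-oxopiperidin-4-yl in place of 1-methyl-1H-pyrazol-4-yl on an amide-type nitrogen. For the measured compounds named here, no measured step touches this amide-type nitrogen, so the measured data give no direct guide to this change. With nothing pointing either way, the expected step of a 1.2-fold higher number from compound 3 to compound 4 (0.08 log units; within the scatter) is put at no change beyond the scatter, with a wide range to cover the unknown. Compound 4 is therefore estimated at 40 nM, with a range from 12 nM to 130 nM in this assay.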

Compound 4, half-maximal inhibitory concentration: 41 nM
Beside the measured number, compound 4's estimate is 1.0-fold (0.01 log units) below it; measured number inside the range.
By their numbers in this assay, from the lowest: compound 1; then compounds 3, 2 and 4 (each within the scatter of the next).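

In this assay, among the compounds shown here, the first measured step on the amide-type nitrogen is a 1.2-fold higher number from compound 3 to compound 4 (0.09 log units; within the scatter), so this position now has a direct reading where the earlier step on the sulfonyl sulfur gave none. Within this pair, 1-methyl-2-oxopiperidin-4-yl, a six-membered non-aromatic ring, takes the place of 1-methyl-1H-pyrazol-4-yl, a five-membered aromatic ring, and the change in ring size, aromatic character and hydrogen-bond acceptor count leaves the number within the scatter; this is one exchange on one amide-type nitrogen and sets no pattern for other groups there. No supporting measurement is available to account for this result.

From the compounds shown here alone, whether a carboxylic acid or a longer alkyl chain on the amide-type nitrogen would move the number beyond the scatter remains open. Going by these compounds, what the ring carbonyl of 1-methyl-2-oxopiperidin-4-yl contributes on its own also stays open, as does the outcome with 1-methylpiperidin-4-yl, a simple amine, on this nitrogen.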